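The source may hold more compounds than are shown below. What is called first, only, known or untested is meant among the compounds shown, and "the series" means these compounds.

Working notes on the series. The shared core is carried by compound 1 `COC(=O)c1sc2cc(-c3ccc(OC)nc3)cnc2c1N` and by compound 2 `COC(=O)c1sc2cc(-c3ccc(C#N)cc3)cnc2c1N`. In a functional assay on NCI-H460 cells (Homo sapiens) for inhibition, read by sulforhodamine B assay, with a stated time of 48 h (on this read-out lower numbers stand for stronger inhibition of growth and higher numbers for weaker inhibition of growth), compound 1 gives only a limit of the assay, > 37500 nM. In this assay compound 2 likewise gives only a limit of the assay, > 75000 nM. For the measured compounds named here, neither value is a number, so no step between the two measured compounds can be counted. Compound 2 stands at one of the two limits shown, (the limit of > 75000 nM in this assay, at which 1 of the 2 values shown sits), while the other value sits at the limit of > 37500 nM in this assay, at which 1 of the 2 values shown sits.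

Compound 3 `COC(=O)c1sc2cc(-c3ccc(OC)cc3)cnc2c1N` is not yet measured. It differs from compound 2 in one place: methoxy in place of cyano on an aromatic carbon. Going by the values given here, with both measured values at limits, no measured step gives a direction. Compound 1 carries a methoxy too and in this assay gives only a limit, > 37500 nM. On that footing compound 3 is expected to show no step beyond the scatter, an at least 1.2-fold lower number from compound 2 to compound 3 (0.09 log units; that floor lies within the scatter). Compound 3 is estimated in this assay at 60000 nM, within 20000 nM to 200000 nM, and a limit rather than a number is the more likely outcome.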

Compound 3, concentration for 50% growth inhibition: > 150000 nM
Compound 3: no number, only a limit; the forecaster's own chance of this, stated with the estimate: 75%; middle value at least 2.5-fold (0.39 log units) from the limit.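

In this assay compound 3 gives only a limit of the assay, > 150000 nM. Compound 2 also stands at a limit, so no step can be read from compound 2 to compound 3 for methoxy in place of cyano. The compounds shown leave open whether any change to the shared core gives a measurable concentration for growth inhibition.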